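This account rests on a few compounds, and the source may have more. Where it says the series, first, only, none or still open, it means among the compounds named here.

Measured compounds:
compound 1 `Cc1cc(C(=O)N2CCCCc3ccccc32)cc(C)c1CNC(=O)Nc1c(F)cccc1F` — 82 nM
compound 2 `COC(=O)CNC(=O)NCc1ccc(C(=O)N2CCCCc3ccccc32)cc1C` — 37 nM
compound 3 `Cc1cc(C(=O)N2CCCCc3ccccc32)ccc1CNC(=O)NCC(=O)OC(C)C` — 140 nM

In a functional assay on HEK293 cells for agonist activity at Vasopressin V2 receptor (Homo sapiens), read by a luciferase reporter and cAMP accumulation (a lower number here means that less compound is needed, a higher number that more compound is needed for the effect), compound 3 gives the highest number of the three. Among the measured compounds shown here, its gap to compound 1 is within the usual scatter, so the two cannot be ordered; against compound 2 the gap is real, a 3.8-fold higher number from compound 2 to compound 3 (0.58 log units; beyond the scatter), the sole change being isopropyl in place of methyl on an oxygen next to a carbonyl group.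

Compound 4 `Cc1cc(C(=O)N2CCCCc3ccccc32)ccc1CNC(=O)NCC(=O)N1CCCCC1` continues from compound 3 with piperidin-1-yl in place of isopropoxy on a carbonyl carbon. For the measured compounds named here, the only measured step touching this part of the molecule is the one from compound 2 to compound 3, an alkyl swap on the ester oxygen, which gave a modest rise. Going by the values given here, replacing the ester oxygen together with its isopropyl by a ring nitrogen is a larger alteration for which no measured pair exists, so the direction cannot be read from the series. The nearby precedent argues that this region tolerates change without drastic loss, and the expected step for compound 4 in this assay is therefore no change at the digits printed from compound 3 to compound 4 (within the scatter), with a wide band around it.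

The estimate for compound 4 is 140 nM, range 45 nM to 450 nM.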

Compound 4, half-maximal effective concentration: 150 nM
Estimate against measurement, compound 4: 1.1-fold (0.03 log units) below; low and high end bracket the measured number.
By their numbers in this assay, from the lowest: compound 2; then compounds 1, 3 and 4 (each within the scatter of the next).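

In this assay, a 1.1-fold higher number from compound 3 to compound 4 (0.03 log units; within the scatter), so at this carbonyl carbon, whose other neighbour is a saturated chain carbon, piperidin-1-yl and isopropoxy cannot be told apart, even though a six-membered non-aromatic ring with a nitrogen now stands where an open group attached through oxygen stood. Until now this position had shown only a swap of alkyl groups on the ester oxygen; the new pair extends it to a change of the atom attached to the carbonyl carbon, and a 4.1-fold higher number from compound 2 to compound 4 (0.61 log units; beyond the scatter), a step that stands beside a 3.8-fold higher number from compound 2 to compound 3 (0.58 log units; beyond the scatter), so among the compounds shown methoxy alone gives the lower number. Nothing available here bears on the reason for these readings.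

Open, on these data alone, is where the free carboxylic acid or a small dimethylamino group on this carbonyl carbon would fall, whether with methoxy or with isopropoxy and piperidin-1-yl. Also open, as far as these compounds go, is whether a morpholine ring, or an amide that keeps its hydrogen, would follow piperidin-1-yl at this carbon.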